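N-methyl removal on the aminopyrimidine linker of compound 1

The source may report more compounds than this note shows. Statements on the series, on what has been measured and on what is new or still open speak of the compounds shown alone.

Within the data shown here, compound 1 `CN(c1ccc(Oc2ncnc3ccsc23)cc1)c1nccc(N2CCCC2)n1` is the lowest of the three numbers so far in a functional assay on A549 cells (Homo sapiens) for inhibition, read by MTT assay, with a stated time of 72 h (a higher number here means a weaker inhibitor, a lower number a stronger inhibitor), where compound 1 gives 6510 nM. Compound 2 `CN(c1ccc(Oc2ncnc3ccsc23)cc1)c1nccc(N2CCc3ccccc3C2)n1` gives 16200 nM in this assay, and compound 3 `CN(c1ccc(Oc2ncnc3sccc23)cc1)c1nccc(N2CCCC2)n1` gives 15100 nM. Both measured steps away from compound 1 run to higher numbers: a 2.5-fold higher number from compound 1 to compound 2 (0.40 log units; beyond the scatter), and a 2.3-fold higher number from compound 1 to compound 3 (0.37 log units; beyond the scatter). Each is modest, yet beyond the scatter, so compound 1 holds its place at the low end of the set.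

Compound 4 `c1cc(N2CCCC2)nc(Nc2ccc(Oc3ncnc4ccsc34)cc2)n1` differs from compound 1 only at the linker nitrogen: hydrogen in place of methyl on a nitrogen on an aromatic ring. Among the measured compounds shown here, neither measured step bears on this place; the step to compound 2 changes the ring on the aromatic carbon and the step to compound 3 swaps the bicyclic group on the oxygen, so there is no precedent for removing the methyl from this nitrogen. With nothing to anchor a direction, the expected step of a 1.2-fold lower number from compound 1 to compound 4 (0.07 log units; within the scatter) is taken as none beyond the scatter, with a wide range to cover either outcome. Compound 4 is therefore estimated at 5500 nM in this assay. The expected range for compound 4 runs from 1500 nM to 20000 nM.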

Compound 4, half-maximal inhibitory concentration: "not active" (no number reported)
Compound 4 has no reported number here; the estimate stays without a comparison.
By their numbers in this assay, from the lowest: compound 1; then compounds 3 and 2 (each within the scatter of the next).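

Among these compounds, compound 4 is reported as "not active" in this assay with no number, so no step from compound 1 to compound 4 can be read. Nothing available explains this result. The compounds shown leave open how far hydrogen in place of methyl on this nitrogen shifts the number, and whether compound 2 or compound 3 would respond alike.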